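The source may hold more compounds than are shown below. What is called first, only, known or untested is meant among the compounds shown, and "the series" means these compounds.

Compound 1 `COc1ccc(-n2c(=O)n(Cc3cc4cc(Cl)ccc4n3CCCC#N)c3cnccc32)cc1OC` in an ADME assay on HeLa cells (Homo sapiens) for cytotoxicity, read by ATP content, with a stated time of 3 days (on this read-out higher numbers stand for lower toxicity in this test and lower numbers for higher toxicity in this test), gives > 50000 nM, which is a limit of the assay and not a number.
Compound 2 `N#CCCCn1c(Cn2c(=O)n(C3CC3)c3ccncc32)cc2cc(Cl)ccc21` gives > 50000 nM, again a limit.
Compound 3 `N#CCCCn1c(Cn2c(=O)n(-c3ccncn3)c3ccncc32)cc2cc(Cl)ccc21` gives > 50000 nM, also a limit.

Compound 3 therefore stands where every measured compound stands: at the limit noted in the limit of > 50000 nM in this assay, at which 3 of the 3 values shown sit, with no number of its own, and the two further values shown are limits as well. None of the three steps among the measured compounds can be read for size: a step that the two limits leave unreadable from compound 1 to compound 2, a step that the two limits leave unreadable from compound 1 to compound 3 and a step that the two limits leave unreadable from compound 2 to compound 3 all lie between two limits. The change from compound 3 to compound 4 `Cc1ccc(-n2c(=O)n(Cc3cc4cc(Cl)ccc4n3CCCC#N)c3cnccc32)cc1` is 4-methylphenyl in place of pyrimidin-4-yl on an aromatic nitrogen. Among the measured compounds shown here, the closest measured step is the one from compound 1 to compound 3, which swapped an aryl group for the same pyrimidin-4-yl at the same aromatic nitrogen without moving the value off the limit, and the other two steps at that nitrogen were equally silent. On this evidence no step beyond the scatter is expected in this assay, in either direction, and the most likely outcome is that compound 4 again reports only a limit. Compound 4 is estimated at 60000 nM, with a range from 20000 nM to 200000 nM. The expected step from compound 3 is a step that the limit leaves unreadable from compound 3 to compound 4.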

Compound 4, half-maximal cytotoxic concentration: > 50000 nM
Compound 4: only a limit was reported; the forecaster's own chance of this, stated with the estimate: 80%; the middle value is on the limit's open side.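

Compound 4 gives > 50000 nM, which is a limit of the assay and not a number, so none of the steps to it from compound 1, compound 2 or compound 3 can be read for size: the limit of > 50000 nM in this assay, at which 4 of the 4 values shown sit.

The compounds shown leave open whether any group at that aromatic nitrogen would bring a measurable value in this assay.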